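The compounds below may be only part of what the source reports. "The series", "measured", "known", "first", "only" and "open" are said of these compounds alone.

Notes on the series. Compound 1 `CC(C)OC(=O)N1CCC(COc2ccc(N3CCN(C(=O)N(C)C)CC3)nc2)CC1` and compound 2 `CCS(=O)(=O)N1CCN(c2ccc(OCC3CCN(C(=O)OC(C)C)CC3)cn2)CC1` share one core and differ only in the group on the amine nitrogen in the ring. In a functional assay on CHO-K1 cells for agonist activity at Glucose-dependent insulinotropic receptor (Homo sapiens), read by a luciferase reporter, with a stated time of 5 h (a higher number here means that more compound is needed for the effect, a lower number that less compound is needed), compound 1 gives > 10000 nM, which is a limit of the assay rather than a number (the limit of > 10000 nM in this assay, at which 1 of the 2 values shown sits). In this assay, among the compounds with values here, compound 2 gives 1300 nM, the only number so far in the set. Within the data shown here, the step of an at least 7.6-fold lower number from compound 1 to compound 2 (0.88 log units; beyond the scatter) is the single measured change available. Compound 3 `CCCS(=O)(=O)N1CCN(c2ccc(OCC3CCN(C(=O)OC(C)C)CC3)cn2)CC1` is not yet measured; it differs from compound 2 by methyl in place of hydrogen on a saturated chain carbon, two bonds along the chain from a sulfonyl sulfur. Among the measured compounds shown here, no measured step bears on a change of this kind: the step of an at least 7.6-fold lower number from compound 1 to compound 2 (0.88 log units; beyond the scatter) replaces the whole group on the ring nitrogen, and nothing yet tracks the chain length on the sulfonyl. The expectation for compound 3 in this assay is therefore a step of a 1.3-fold lower number from compound 2 to compound 3 (0.11 log units; within the scatter) that stays within the scatter. Compound 3 is estimated at 1000 nM, with a range from 400 nM to 3000 nM.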

Compound 3, half-maximal effective concentration: 300 nM
Beside the measured number, compound 3's estimate is 3.3-fold (0.52 log units) above it, outside the stated range (below it).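

The sulfonyl chain is a position that responds in this assay: going from ethylsulfonyl to propylsulfonyl, one methyl on a saturated chain carbon, two bonds along the chain from a sulfonyl sulfur, gives a 4.3-fold lower number from compound 2 to compound 3 (0.64 log units; beyond the scatter). The earlier step replaced the whole group on the ring nitrogen, whereas this one shows that a change within the sulfonyl group alone moves the number beyond the scatter, and the largest gap in the set is now an at least 33-fold lower number from compound 1 to compound 3 (1.52 log units; beyond the scatter). That gap rests on a limit of the assay for compound 1, not on a number: the limit of > 10000 nM in this assay, at which 1 of the 3 values shown sits.

As far as these compounds go, two sulfonyl compounds make one step and not a trend, so it stays open whether a butyl chain would continue the change. From the compounds shown here alone, the effect of a branched group such as isopropyl or of a ring such as cyclopropyl on the sulfonyl is also open.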